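A few compounds are considered here, and "the series" means these few. Any claim that something is new, unique, unknown or untested is made for them only; others in the source may bear on it.

Cytotoxicity notes on the series. In an ADME assay on Vero cells (Chlorocebus sabaeus) for cytotoxicity (on this read-out higher numbers stand for lower toxicity in this test and lower numbers for higher toxicity in this test), compound 1 `CN1CCN(CC(=O)Nc2ccc(-c3nc4cc(C(F)(F)F)ccc4n3C)cc2)CC1` gives > 100000 nM, which is a limit of the assay and not a number. Compound 2 `C#C[C@@]1(O)[C@H](O)[C@@H](CO)O[C@H]1n1ccc(N)nc1=O` likewise returns a limit, > 100000 nM. Compound 3 `O=C(CN1CCCC1)Nc1ccc(-c2nc3ccccc3[nH]2)cc1` also stops at a limit, > 100000 nM. Thus compound 1 stands where every value so far stands, namely at the limit of > 100000 nM in this assay, at which 3 of the 3 values shown sit, and nothing separates it from the other two. Compound 4 `Cn1c(-c2ccc(N)cc2)nc2cc(C(F)(F)F)ccc21` differs from compound 1 in one place: hydrogen in place of ((4-methylpiperazin-1-yl)methyl)carbonyl on a nitrogen on an aromatic ring. Among the measured compounds shown here, no step between measured compounds is at hand, so any expectation rests on the three limits alone. For compound 4 the expected step of a number no higher from compound 1 to compound 4 (the limit leaves the size open) in this assay is none beyond the usual scatter. Compound 4 is estimated at 100000 nM in this assay, with a range from 40000 nM to 250000 nM, and most probably again reported only as a limit.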

Compound 4, half-maximal cytotoxic concentration: > 100000 nM
Compound 4: no number, only a limit (the forecaster's own chance of this, stated with the estimate: 70%); the middle value sits exactly at the limit.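

No step can be read from compound 1 to compound 4, as both values in this assay are limits and not numbers: the limit of > 100000 nM in this assay, at which 4 of the 4 values shown sit.

The compounds shown leave open whether hydrogen in place of ((4-methylpiperazin-1-yl)methyl)carbonyl changes this read-out at all.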